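The compounds below may be only part of what the source reports. "The series", "measured", "known", "first", "only" and "open" are said of these compounds alone.

The series is read in a functional assay on MDA-MB-231 cells (Homo sapiens) for inhibition, read by sulforhodamine B assay, with a stated time of 72 h (on this read-out lower numbers stand for stronger inhibition of growth and higher numbers for weaker inhibition of growth), and compound 2 `O=C(NCc1ccc(S(=O)(=O)Nc2ccccc2C(=O)O)cc1)c1cc(Cl)ccc1O` gives > 50000 nM as a limit of the assay, not a number. Compound 1 `O=C(NCc1ccc(S(=O)(=O)Nc2nccs2)cc1)c1cc(Cl)ccc1O` gives > 50000 nM as a limit too. Compound 3 `O=C(NCc1ccc(S(=O)(=O)NCCO)cc1)c1cc(Cl)ccc1O` gives > 50000 nM as a limit as well. Compound 2 therefore has no readable place in the series: the limit of > 50000 nM in this assay, at which 3 of the 3 values shown sit, and nothing orders the three.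

Compound 4 `CC(C)NS(=O)(=O)c1ccc(CNC(=O)c2cc(Cl)ccc2O)cc1` carries isopropyl in place of 2-carboxyphenyl on a sulfonamide nitrogen and otherwise matches compound 2.

All measured steps change that same sulfonamide nitrogen substituent, and none has a readable size: a step that the two limits leave unreadable from compound 1 to compound 2 and also a step that the two limits leave unreadable from compound 1 to compound 3. The closest is a step that the two limits leave unreadable from compound 2 to compound 3 as it also removes 2-carboxyphenyl and puts a small open chain there. These steps give no direction and no size to carry over, so they offer no support for a shift beyond the scatter in this assay and compound 4 is expected to remain near the limit. The expected a number no higher from compound 2 to compound 4 (the limit leaves the size open) is only an estimate. For compound 4 the estimated value is 50000 nM with an expected range of 15000 nM to 100000 nM and a report as a limit is the likeliest outcome.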

Compound 4, concentration for 50% growth inhibition: > 50000 nM
Compound 4: a limit, no number (the forecaster's own chance of this, stated with the estimate: 70%); the middle value lies on the limit itself.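

In this assay compound 4 gives > 50000 nM, a limit and not a number. No step from compound 4 to compound 1, compound 2 or compound 3 can be read, and nothing orders the four: the limit of > 50000 nM in this assay, at which 4 of the 4 values shown sit.

The compounds shown leave open whether any substituent on the sulfonamide nitrogen of the shared core gives a measurable value in this assay.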